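A Methylphenyl Ether in Place of an Iodophenyl Ether

The source may hold more compounds than are shown below. What is called first, only, known or untested is meant among the compounds shown, and "the series" means these compounds.

Among the measured compounds shown here, compound 2 `Cc1nn(C)c(Oc2ccc(I)cc2)c1/C=N\CCCCCCOc1cc2oc(=O)cc(C)c2cc1Cl` is the weaker of the two compounds measured so far: in a functional assay on SMMC-7721 cells (Homo sapiens) for antiproliferative activity, read by MTT assay, with a stated time of 72 h (a higher number here means a weaker inhibitor, a lower number a stronger inhibitor), compound 2 gives 13300 nM, the highest number of the pair. Its nearest neighbour, compound 1 `Cc1nn(C)c(Oc2ccc(Br)cc2)c1/C=N\CCCCCCOc1cc2oc(=O)cc(C)c2cc1Cl`, differs only in the halogen on the aryl ether, and in this assay compound 1 gives 3090 nM. For the measured compounds named here, the single step between them, a 4.3-fold higher number from compound 1 to compound 2 (0.63 log units; beyond the scatter), shows that a change on that ring alone can move the number by a modest but real amount.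

Compound 3 `Cc1ccccc1Oc1c(/C=N\CCCCCCOc2cc3oc(=O)cc(C)c3cc2Cl)c(C)nn1C` has not yet been measured. It differs from compound 2 in that (2-methylphenyl in place of 4-iodophenyl on an oxygen on an aromatic ring). Going by the values given here, no measured step covers such a change; the one step recorded concerns bromo against iodo, not a halogen against a methyl group, so its modest size is the only guide. Since compound 1 gives 3090 nM with the smaller halogen, compound 3 is expected to return a lower number than its iodo predecessor, a step estimated as a 2.7-fold lower number from compound 2 to compound 3 (0.42 log units; beyond the scatter). Compound 3 is therefore expected to come out near 5000 nM, most likely between 1500 nM and 20000 nM.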

Compound 3, half-maximal inhibitory concentration: 5120 nM
Beside the measured number, compound 3's estimate is 1.0-fold (0.01 log units) below it; measured number inside the range.
By their numbers in this assay, from the lowest: compounds 1 and 3 (each within the scatter of the next); then compound 2.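

In this assay, the swap on the oxygen gives a 2.6-fold lower number from compound 2 to compound 3 (0.41 log units; beyond the scatter), so this position does not need a halogen on the ring to reach the better numbers of the series, and the earlier bromo and iodo pair could not show that. The step of a 1.7-fold higher number from compound 1 to compound 3 (0.22 log units; within the scatter) sets 2-methylphenyl and 4-bromophenyl level in this assay, which leaves compound 2, with its 4-iodophenyl, as the only one of the three standing apart and the weakest of them. Nothing available here explains why the iodo compound stands apart.

The change from 4-iodophenyl to 2-methylphenyl alters both the group and its numbered place on the ring, so the three compounds cannot say which of the two accounts for the step. A 4-methylphenyl or a 2-iodophenyl ether would separate those two parts, while an unsubstituted phenyl ether, or a ring carrying an amine or a carboxylic acid, remains outside what these compounds cover.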